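The source may report more compounds than this note shows. Statements on the series, on what has been measured and on what is new or still open speak of the compounds shown alone.

Measured compounds:
compound 1 `O=C(O)c1ccc(-c2cnc(C(=O)CCCCCCc3ccccc3)o2)cc1` gives 60 nM
compound 2 `Cc1cccnc1-c1cnc(C(=O)CCCCCCc2ccccc2)o1` gives 15 nM
compound 3 `O=C(CCCCCCc1ccccc1)c1ncc(-c2ccncn2)o1` gives 2.3 nM

All three were tested in an assay (Rattus norvegicus) for inhibition of Fatty-acid amide hydrolase 1 (Homo sapiens); on this read-out lower numbers stand for stronger inhibition and higher numbers for weaker inhibition. Among them compound 3 stands at the lowest number, with 2.3 nM. Its nearest neighbour is compound 2, as the step of a 6.5-fold lower number from compound 2 to compound 3 (0.81 log units; beyond the scatter) shows, and the step of a 26-fold lower number from compound 1 to compound 3 (1.42 log units; beyond the scatter) is larger still. The step of a 4.0-fold lower number from compound 1 to compound 2 (0.60 log units; beyond the scatter) shows that exchanging the ring attached to the shared core changes the number by a modest amount.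

Compound 4 `O=C(CCCCCCc1ccccc1)c1ncc(-c2ncccn2)o1` differs from compound 3 in one place: pyrimidin-2-yl in place of pyrimidin-4-yl on an aromatic carbon. Among the measured compounds shown here, no measured step exchanges one pyrimidinyl ring for another; the three measured steps each replace one kind of ring by a different kind and range from modest to large. A step no larger than modest is therefore expected, and its direction cannot be read from the measured steps, though a slight rise toward the number of compound 2 seems the more likely case. The estimate for compound 4 is 5 nM, with a range from 1.2 nM to 20 nM. The expected step is a 2.2-fold higher number from compound 3 to compound 4 (0.34 log units; beyond the scatter).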

Compound 4, inhibition constant: 5.3 nM
Compound 4: the middle estimate sits 1.1-fold (0.03 log units) below what was measured; low and high end bracket the measured number.
By their numbers in this assay, from the lowest: compound 3; then compound 4; then compound 2; then compound 1.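

Pyrimidin-2-yl in place of pyrimidin-4-yl keeps the same atoms and only joins them differently, yet in this assay it gives a 2.3-fold higher number from compound 3 to compound 4 (0.36 log units; beyond the scatter), so at this position the arrangement of atoms within the ring shifts the number on its own. The new ring also keeps a clear lead over the two earlier, weaker rings: in place of 3-methylpyridin-2-yl it gives a 2.8-fold lower number from compound 2 to compound 4 (0.45 log units; beyond the scatter), and in place of 4-carboxyphenyl it gives an 11-fold lower number from compound 1 to compound 4 (1.05 log units; beyond the scatter). No measurement shown here accounts for the difference between the two pyrimidinyl rings.

Where a pyrimidin-5-yl ring, a plain phenyl ring or a pyridine ring without the methyl group would fall in this order remains open. Also open, as far as these compounds go, is whether the order of the rings would hold with a shorter chain on the carbonyl.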